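A few compounds are considered here, and "the series" means these few. Any claim that something is new, unique, unknown or untested is made for them only; others in the source may bear on it.

Three compounds have been measured in an ADME assay on microsomes from liver (Homo sapiens) for metabolic stability, tested at 2.5 uM; a higher number here means faster removal of the compound, a lower number slower removal:

compound 1, `COc1cccc(-c2c(S(=O)(=O)c3ccc(C)c(F)c3)cnc3c(F)cccc23)c1`, 4.02 mL/min
compound 2, `COc1ccc(S(=O)(=O)c2cnc3c(F)cccc3c2-c2cccc(Cl)c2)cc1`, 2.75 mL/min
compound 3, `Cc1ccc(S(=O)(=O)c2cnc3c(F)cccc3c2-c2ccc(Cl)cc2)cc1F`, 2.2 mL/min

Compound 3 gives the lowest of the three numbers; the nearest is compound 2 and the furthest compound 1, and both gaps lie within the usual scatter, so no order among the three can be claimed. Compound 4, `Cc1ccc(S(=O)(=O)c2cnc3c(F)cccc3c2-c2cccc(Cl)c2)cc1F`, is not yet measured. Relative to compound 3 the change is 3-chlorophenyl in place of 4-chlorophenyl on an aromatic carbon. Going by the values given here, no measured step covers this exchange. Among the compounds with values here, the only measured step, a 1.8-fold lower number from compound 1 to compound 3 (0.26 log units; within the scatter), concerns a different change and stays within the scatter. Compound 2 carries a 3-chlorophenyl at the same place but differs from compound 3 elsewhere, and its number lies within the scatter of compound 3. The step is therefore expected to be a 1.1-fold higher number from compound 3 to compound 4 (0.06 log units; within the scatter). For compound 4 the estimate is 2.5 mL/min, with a range of 1.3 mL/min to 4.8 mL/min.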

Compound 4, intrinsic clearance in a liver preparation (reported as CLH), per the amount of preparation that the assay uses: 3.18 mL/min
Beside the measured number, compound 4's estimate is 1.3-fold (0.10 log units) below it, and the stated range covers the measured number.
By their numbers in this assay, from the lowest: compounds 3, 2, 4 and 1 (each within the scatter of the next).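

Moving the chlorine at this place, with 3-chlorophenyl in place of 4-chlorophenyl, leaves the number in this assay within the scatter (a 1.4-fold higher number from compound 3 to compound 4 (0.16 log units; within the scatter)). The two other exchanges read from compound 4 also stay within the scatter: 3-fluoro-4-methylphenyl in place of 4-methoxyphenyl on the sulfonyl sulfur (a 1.2-fold higher number from compound 2 to compound 4 (0.06 log units; within the scatter)), and chloro in place of methoxy (a 1.3-fold lower number from compound 1 to compound 4 (0.10 log units; within the scatter)). Nothing available explains these steps.

Still open, from the compounds shown here alone, is whether an amine or a carboxylic acid on this phenyl ring would give a step beyond the scatter.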